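Amide chain extension on compound 3: expectation before measurement

The source may report more compounds than this note shows. Statements on the series, on what has been measured and on what is new or still open speak of the compounds shown alone.

compound 1 `CCNC(=O)c1cc(Oc2ccc(NC(=O)c3cc4cccnc4n(-c4ccc(Cl)cc4)c3=O)cc2)ccn1`: 330 nM
compound 2 `CCNC(=O)c1cc(Oc2ccc(NC(=O)c3cc4cccnc4n(-c4ccc(Br)cc4)c3=O)cc2)ccn1`: 1160 nM
compound 3 `CCNC(=O)c1cc(Oc2ccc(NC(=O)c3cc4cccnc4n(-c4ccc(F)c(Cl)c4)c3=O)cc2)ccn1`: 2600 nM

All three were read in a functional assay on HT-29 cells (Homo sapiens) for antiproliferative activity, read by MTT assay, with a stated time of 72 h; a lower number here means a stronger inhibitor, a higher number a weaker inhibitor. Compound 3 gives the highest number of the three: a 7.9-fold higher number from compound 1 to compound 3 (0.90 log units; beyond the scatter) and a 2.2-fold higher number from compound 2 to compound 3 (0.35 log units; beyond the scatter), both beyond the scatter, while a 3.5-fold higher number from compound 1 to compound 2 (0.55 log units; beyond the scatter) separates the other two. Compound 4 `CCCNC(=O)c1cc(Oc2ccc(NC(=O)c3cc4cccnc4n(-c4ccc(F)c(Cl)c4)c3=O)cc2)ccn1` keeps everything in compound 3 except one change, (methyl in place of hydrogen on a saturated chain carbon, two bonds along the chain from an amide-type nitrogen). For the measured compounds named here, none of the measured steps touches this part of the molecule; each of them alters only the group on the aromatic nitrogen, and the amide chain is the same in compounds 1, 2 and 3. Going by the values given here, there is thus no step to carry over, and no movement beyond the scatter is expected, no change at the digits printed from compound 3 to compound 4 (within the scatter). Compound 4 is estimated at 2600 nM, within 1200 nM to 5600 nM.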

Compound 4, half-maximal inhibitory concentration: 920 nM
Compound 4: the middle estimate sits 2.8-fold (0.45 log units) above what was measured, and the stated range ends above it.
By their numbers in this assay, from the lowest: compound 1; then compounds 4 and 2 (each within the scatter of the next); then compound 3.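

The amide chain is a live position in this assay: ethylamino to propylamino gives a 2.8-fold lower number from compound 3 to compound 4 (0.45 log units; beyond the scatter) and this is a shift that compounds 1, 2 and 3 could not reveal, since all three carry the same chain. The step is read only with the 3-chloro-4-fluorophenyl group on the aromatic nitrogen. No available evidence accounts for the shift.

From the compounds shown here alone, whether a longer chain, such as butylamino, or a terminal amine would extend or reverse this shift remains open. So does whether propylamino acts the same way alongside the 4-chlorophenyl group of compound 1.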